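Swapping the Chalcone Arm on a Pyrazolopyrimidine Core

The compounds below may be only part of what the source reports. "The series", "measured", "known", "first", "only" and "open" are said of these compounds alone.

Measured compounds:
- compound 1, `COc1ccc(/C=C/C(=O)c2cc(-c3ccc(OC)c(OC)c3)n3nc(-c4ccccc4)cc3n2)cc1`: 22000 nM
- compound 2, `COc1ccc(-c2cc(/C=C/C(=O)c3ccc(OC)c(OC)c3)nc3cc(-c4ccccc4)nn23)cc1`: 8700 nM

Both compounds were tested in a functional assay on MDA-MB-231 cells (Homo sapiens) for antiproliferative activity, read by MTT assay, with a stated time of 24 h; a lower number here means a stronger inhibitor, a higher number a weaker inhibitor. Compound 1 gives 22000 nM, the higher of the two numbers; compound 2 gives 8700 nM, a lower number that lies beyond the scatter. Compound 3, `COc1ccc(-c2cc(/C=C/C(=O)c3ccc(C)c(C)c3)nc3cc(-c4ccccc4)nn23)cc1OC`, has not yet been measured. It differs from compound 1 in one place: 2-((3,4-dimethylphenyl)carbonyl)ethenyl in place of (2-(4-methoxyphenyl)ethenyl)carbonyl on an aromatic carbon. Within the data shown here, the chain entering compound 3 carries a 3,4-dimethylphenyl group on its carbonyl, whereas compound 2, the only other measured compound, carries a 3,4-dimethoxyphenyl group on its carbonyl. Among the measured compounds shown here, with no measured pair for this exact change, the size of the step is uncertain. A modest move toward a lower number of about a 2.0-fold lower number from compound 1 to compound 3 (0.30 log units; within the scatter) is expected. Compound 3 is therefore estimated at 11000 nM, with a likely range from 3500 nM to 35000 nM.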

Compound 3, half-maximal inhibitory concentration: 11500 nM
Compound 3: the middle estimate sits 1.0-fold (0.02 log units) below what was measured, and the stated range covers the measured number.
By their numbers in this assay, from the lowest: compounds 2, 3 and 1 (each within the scatter of the next, the first and the last beyond it).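

On this aromatic carbon of the shared core, an arm joined through its carbonyl gives way to one joined through its ethenyl and ending in a 3,4-dimethylphenyl group, and the outcome in this assay is a 1.9-fold lower number from compound 1 to compound 3 (0.28 log units; within the scatter). Even a swap that rebuilds the whole arm therefore leaves the two compounds indistinguishable in this test, so this position accepts either arm without a measurable difference. Nothing available explains this result.

On these data alone, the swap alters the direction of the arm and the groups on its phenyl ring together, so the contribution of each part alone stays unknown. As far as these compounds go, whether an amine, a carboxylic acid or a longer chain on this carbon would shift the number beyond the scatter also remains open.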